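The compounds below may be only part of what the source reports. "The series", "measured", "known", "first", "only" and "open" are said of these compounds alone.

Working notes on the series. Compound 1 `COc1ccc(-c2csc(C(=O)N(C)C)c2)cc1S(=O)(=O)Nc1cccc(NCCNC(=O)c2cccc(C)c2)c1` carries a 5-(dimethylcarbamoyl)thiophen-3-yl group on the shared core; in a functional assay on CHO-RD-HGA16 cells for agonist activity at Orexin/Hypocretin receptor type 1 (Homo sapiens), read by fluorescence and calcium flux, with a stated time of 30 min (a lower number here means that less compound is needed, a higher number that more compound is needed for the effect), compound 1 gives 1330 nM. Compound 2 `COc1ccc(/C=C/C(=O)N(C)C)cc1S(=O)(=O)Nc1cccc(NCCNC(=O)c2cccc(C)c2)c1` has 2-(dimethylcarbamoyl)ethenyl at that position instead. For compound 2 this assay reports only a limit, > 10000 nM. The step of an at least 7.5-fold higher number from compound 1 to compound 2 (0.87 log units; beyond the scatter) is thus a loss of at least that size, and compound 2 stands at the limit of > 10000 nM in this assay, at which 1 of the 2 values shown sits, the weaker end of the two values shown. Compound 3 `COc1ccc(CCC(=O)N(C)C)cc1S(=O)(=O)Nc1cccc(NCCNC(=O)c2cccc(C)c2)c1` differs from compound 2 by 2-(dimethylcarbamoyl)ethyl in place of 2-(dimethylcarbamoyl)ethenyl on an aromatic carbon, the open chain kept and only its double bond removed. Among the measured compounds shown here, the single measured step that bears on an open chain at this position is an at least 7.5-fold higher number from compound 1 to compound 2 (0.87 log units; beyond the scatter), which carried the number out of the measurable range, so the saturated chain of compound 3 has no precedent of its own. In this assay compound 3 is expected to sit near the limit again, the step that the limit leaves unreadable from compound 2 to compound 3 estimated as none beyond the scatter. The estimate for compound 3 is 15000 nM, in the range 3000 nM to 60000 nM, with a limit-only read-out the likelier outcome.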

Compound 3, half-maximal effective concentration: > 10000 nM
Compound 3 gave a limit, no number; the forecaster's own chance of this, stated with the estimate: 70%; the middle value is on the limit's open side.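

Removing the double bond of the open chain does not bring back a number in this assay: an at least 7.5-fold higher number from compound 1 to compound 3 (0.87 log units; beyond the scatter), so the loss at this position is not tied to the double bond of compound 2. Compound 2 and compound 3 both give limits, so the step between them cannot be read and no order between the ethenyl and the ethyl chain can be stated. Among the groups shown at this position, only the 5-(dimethylcarbamoyl)thiophen-3-yl group of compound 1 gives a number, while both open chains end at the same read-out: the limit of > 10000 nM in this assay, at which 2 of the 3 values shown sit.

Open, from the compounds shown here alone, is whether the number of compound 1 rests on the ring or on the dimethylcarbamoyl group it carries; an unsubstituted thiophen-3-yl group or a phenyl ring bearing the same dimethylcarbamoyl group would separate the two. Also open, going by these compounds, is whether an open chain with a carboxylic acid or an amine in place of the dimethylcarbamoyl group, or a longer chain, would give a number at this position at all.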